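A few compounds are considered here, and "the series" means these few. Any claim that something is new, unique, unknown or untested is made for them only; others in the source may bear on it.

Measured so far in a functional assay on HEK293 cells for agonist activity at D(4) dopamine receptor (Homo sapiens), read by FLIPR; a lower number here means a smaller maximal response, a higher number a larger maximal response:

- compound 1 `O=C(CN1CCC(c2cccc[n+]2[O-])CC1)Nc1cccc(Cl)c1`: 76%
- compound 2 `Cc1cc(C)cc(NC(=O)CN2CCC(c3cccc[n+]3[O-])CC2)c1`: 76%
- compound 3 `O=C(CN1CCC(c2cccc[n+]2[O-])CC1)Nc1ccc(F)cc1F`: 74%

Compound 1 stands level with compound 2 at the digits shown, the two together the highest of the three values, while compound 3 lies slightly lower; all of this lies within the scatter, as the steps show: no change at the digits printed from compound 1 to compound 2 (within the scatter), a number 2 percentage points lower from compound 1 to compound 3 (within the scatter) and a number 2 percentage points lower from compound 2 to compound 3 (within the scatter). Compound 4 `O=C(CN1CCC(c2cccc[n+]2[O-])CC1)Nc1cccc(C(F)(F)F)c1` differs from compound 1 in one place: trifluoromethyl in place of chloro on an aromatic carbon. Going by the values given here, no measured step changes exactly this substituent, but each of the three steps exchanges the substitution pattern of the same aryl ring and none moves the maximal response beyond the scatter. He therefore expects a step of a number 1 percentage points lower from compound 1 to compound 4 (within the scatter), no change beyond the scatter, and estimates compound 4 at 75%, between 62% and 88%.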

Compound 4, largest response reached (reported as efficacy), in percent of the reference or control that the assay uses: 75%
For compound 4 middle estimate and measured number coincide at the digits printed; the range from low to high includes it.
By their numbers in this assay, from the lowest: compounds 3, 4, 1 and 2 (each within the scatter of the next).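

In this assay, trifluoromethyl in place of chloro gives a number 1 percentage points lower from compound 1 to compound 4 (within the scatter) on this aromatic carbon, so a single substituent exchange at this position, larger by heavy-atom count, leaves the maximal response within the scatter. The earlier steps shown here exchanged whole substitution patterns on the aryl ring and did not isolate this one place. No available evidence bears on this result. The compounds shown leave open whether an amine, a carboxylic acid or a longer chain on this carbon would also keep the maximal response within the scatter.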